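Replacing piperidinyl with propanoylamino on the oxazolidinone side chain

A few compounds are considered here, and "the series" means these few. Any claim that something is new, unique, unknown or untested is made for them only; others in the source may bear on it.

Measured compounds:
compound 1, `CN(CCC#N)C[C@H]1CN(c2ccc(-n3cc(-c4ccccn4)cn3)c(F)c2)C(=O)O1`: 1.9
compound 2, `O=C1O[C@@H](CN2CCCCC2)CN1c1ccc(-n2cc(-c3ccccn3)cn2)c(F)c1`: 3.1
compound 3, `CC(=O)OC[C@H]1CN(c2ccc(-n3cc(-c4ccccn4)cn3)c(F)c2)C(=O)O1`: 2.09

Of the compounds shown here, three sharing one core have been measured in a physicochemical assay for lipophilicity, read by HPLC, measured as octanol-water partition; a lower number here means a more polar compound, a higher number a more lipophilic compound. Compound 2 stands highest of the three; its nearest neighbour is compound 3, and the step of a number 1.01 log units lower from compound 2 to compound 3 (beyond the scatter) is beyond the scatter, while the step of a number 1.20 log units higher from compound 1 to compound 2 (beyond the scatter) is larger still. Compound 1 and compound 3 lie within the scatter of each other, as the step of a number 0.19 log units higher from compound 1 to compound 3 (within the scatter) shows.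

Compound 4, `CCC(=O)NC[C@H]1CN(c2ccc(-n3cc(-c4ccccn4)cn3)c(F)c2)C(=O)O1`, has not yet been measured. It differs from compound 2 in one place: propanoylamino in place of piperidin-1-yl on a saturated chain carbon bound to a saturated ring carbon

The step that bears most directly on this change is a number 1.01 log units lower from compound 2 to compound 3 (beyond the scatter), where another group without a ring took the place of piperidin-1-yl at the same position and the number fell by a large amount. The step of a number 1.20 log units higher from compound 1 to compound 2 (beyond the scatter) points the same way: each measured replacement of piperidin-1-yl at this position has moved the number down well beyond the scatter. Compound 4 is therefore expected to sit clearly below compound 2, by a step estimated at a number 1.30 log units lower from compound 2 to compound 4 (beyond the scatter). For compound 4 the estimated value in this assay is 1.8, with a range from 1.3 to 2.3.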

Compound 4, partition coefficient: 2.2
Compound 4: the middle estimate sits 0.40 log units below what was measured; measured number inside the range.
By their numbers in this assay, from the lowest: compounds 1, 3 and 4 (each within the scatter of the next); then compound 2.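

In this assay, propanoylamino, with a number 0.90 log units lower from compound 2 to compound 4 (beyond the scatter) as its step, makes a third group without a ring that stands clearly under piperidin-1-yl at this place on the saturated chain carbon. It is the only group shown that brings a hydrogen-bond donor, yet a number 0.11 log units higher from compound 3 to compound 4 (within the scatter) against acetoxy and a number 0.30 log units higher from compound 1 to compound 4 (within the scatter) against (2-cyanoethyl)(methyl)amino leave these three compounds together, with compound 2 alone apart from them. Nothing measured here gives a reason for this grouping.

Going by these compounds, whether the ring of piperidin-1-yl is what separates compound 2 remains open, and an open-chain tertiary amine such as diethylamino would test that at this place. A longer acyl chain such as butanoylamino would show whether the number moves with the length of the amide chain.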